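A longer chain on compound 2

A few compounds are considered here, and "the series" means these few. Any claim that something is new, unique, unknown or untested is made for them only; others in the source may bear on it.

compound 1 `CC(C)C(=O)OCCc1c(-c2ccccc2Cl)c2cc(Cl)ccc2[nH]c1=O` gives 62000 nM
compound 2 `CCCC(=O)OCCc1c(-c2ccccc2Cl)c2cc(Cl)ccc2[nH]c1=O` gives 52000 nM

Within the data shown here, in an ADME assay on HepG2 2.2.15 cells (Homo sapiens) for cytotoxicity (a higher number here means that more compound is tolerated, a lower number that less compound is tolerated), compound 2 gives 52000 nM and sits within the scatter of compound 1, its only neighbour so far. Compound 3 `CCCCCCCC(=O)OCCc1c(-c2ccccc2Cl)c2cc(Cl)ccc2[nH]c1=O` carries a larger change: butyl in place of hydrogen on a saturated chain carbon, three bonds along the chain from a carbonyl carbon. Among the measured compounds shown here, one measured step bears on this: a 1.2-fold lower number from compound 1 to compound 2 (0.08 log units; within the scatter) for propyl in place of isopropyl on a carbonyl carbon. It lies within the scatter but involves a smaller change, so it is a thin guide. No step beyond the scatter is expected in this assay here. The estimate means a 1.2-fold lower number from compound 2 to compound 3 (0.06 log units; within the scatter) as the expected step. Compound 3 is expected at 45000 nM (estimated range 18000 nM to 90000 nM).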

Compound 3, half-maximal cytotoxic concentration: 78000 nM
For compound 3 the middle estimate is 1.7-fold (0.24 log units) below the measured one, within the range that was stated.
By their numbers in this assay, from the lowest: compounds 2, 1 and 3 (each within the scatter of the next).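

In this assay butyl in place of hydrogen gives a 1.5-fold higher number from compound 2 to compound 3 (0.18 log units; within the scatter) and heptyl in place of isopropyl gives a 1.3-fold higher number from compound 1 to compound 3 (0.10 log units; within the scatter) on the same shared core. So even this much larger change on the chain at the carbonyl carbon stays within the scatter, which the small earlier step could not show. Nothing available explains this result. The compounds shown leave open whether an amine or a carboxylic acid at the end of this chain, or a ring in its place, would give a step beyond the scatter.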